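The compounds below may be only part of what the source reports. "The series", "measured", "known", "first", "only" and "open" are said of these compounds alone.

Measured in a functional assay on HL-60 cells (Homo sapiens) for antiproliferative activity, read by XTT assay, with a stated time of 72 h; on this read-out lower numbers stand for stronger inhibition and higher numbers for weaker inhibition:
- compound 1 `O=c1[nH]cnc2c1c(-c1cc3ccccc3o1)cn2[C@@H]1O[C@H](CO)[C@@H](O)[C@H]1O`: > 20000 nM
- compound 2 `Cc1nc(N)c2c(-c3ccsc3)cn([C@@H]3O[C@H](CO)[C@@H](O)[C@H]3O)c2n1`: > 20000 nM
- compound 3 `Cc1nc(N)c2c(-c3ccccc3)cn([C@@H]3O[C@H](CO)[C@@H](O)[C@H]3O)c2n1`: > 20000 nM

All three entries are limits and not numbers: the limit of > 20000 nM in this assay, at which 3 of the 3 values shown sit. Compound 3 stands only at its limit of > 20000 nM. For the measured compounds named here, the one measured step is a step that the two limits leave unreadable from compound 2 to compound 3, so it offers no size to carry forward.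

Compound 4 `Cc1nc(N)c2c(I)cn([C@@H]3O[C@H](CO)[C@@H](O)[C@H]3O)c2n1` has iodo in place of phenyl on an aromatic carbon of the shared core: iodo in place of phenyl on an aromatic carbon. Going by the values given here, no measured compound carries iodo. A step towards stronger inhibition is expected in this assay, but only a modest one, and compound 4 may stay at the limit.

The expected change is an at least 1.6-fold lower number from compound 3 to compound 4 (0.22 log units; that floor lies within the scatter).

For compound 4 the estimate is 12000 nM, with an expected range of 2000 nM to 40000 nM.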

Compound 4, half-maximal inhibitory concentration: 2050 nM
For compound 4 the middle estimate is 5.9-fold (0.77 log units) above the measured one; the measured number falls inside the stated range.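

At this aromatic carbon of the five-membered ring, iodo gives the series its first readable number in this assay, with an at least 9.7-fold lower number from compound 3 to compound 4 (0.98 log units; beyond the scatter) and an at least 9.7-fold lower number from compound 2 to compound 4 (0.98 log units; beyond the scatter). A single iodine atom in place of either aromatic ring therefore moves the value clear of the limit. The step between compound 2 and compound 3 cannot be read, as both values are limits: the limit of > 20000 nM in this assay, at which 3 of the 4 values shown sit.

As far as these compounds go, whether the change follows from iodine itself or from the loss of the ring stays open. So does the outcome with bromo, methyl, an amine or a longer chain on this carbon.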